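A Same-Sized Group Exchanged on an Amide-Type Nitrogen

A few compounds are considered here, and "the series" means these few. Any claim that something is new, unique, unknown or untested is made for them only; others in the source may bear on it.

Compound 1 `CC1=CC[C@@H]([C@@](C)(O)CCCC(C)(C)NC(=S)NN)CC1` gave > 100000 nM in a functional assay on OVCAR-3 cells (Homo sapiens) for cytotoxicity, read by sulforhodamine B assay (on this read-out higher numbers stand for weaker inhibition of growth and lower numbers for stronger inhibition of growth), which is a limit of the assay and not a number. Among the measured compounds shown here, compound 2 `CC1=CC[C@@H]([C@@](C)(O)CCCC(C)(C)NC(=S)N/N=C\c2ccc(O)cc2)CC1` gave 17400 nM in this assay, the only true number so far. For the measured compounds named here, the single measured step is an at least 5.7-fold lower number from compound 1 to compound 2 (0.75 log units; beyond the scatter), where a group of 9 heavy atoms with one six-membered aromatic ring of carbon only takes the place of one nitrogen atom, on an amide-type nitrogen.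

Compound 3 `CC1=CC[C@@H]([C@@](C)(O)CCCC(C)(C)NC(=S)N/N=C(/C)c2ccccc2)CC1` keeps the shared core, and the change from compound 2 is a group of 9 heavy atoms (8 carbon, 1 nitrogen; one six-membered aromatic ring of carbon only) in place of a group of 9 heavy atoms (7 carbon, 1 nitrogen, 1 oxygen; one six-membered aromatic ring of carbon only), on an amide-type nitrogen. The measured step bears on this only indirectly, since it does not measure an exchange of one such group for another. The entering group still holds one six-membered aromatic ring of carbon only, so the gain seen in an at least 5.7-fold lower number from compound 1 to compound 2 (0.75 log units; beyond the scatter) is expected to be largely kept. The estimated 1.3-fold higher number from compound 2 to compound 3 (0.10 log units; within the scatter) stays within the scatter. For compound 3 the expected value is 22000 nM, with an estimated range of 8000 nM to 70000 nM.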

Compound 3, concentration for total growth inhibition: 59500 nM
For compound 3 the middle estimate is 2.7-fold (0.43 log units) below the measured one; the measured number falls inside the stated range.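

Two groups of the same heavy-atom count, each holding one six-membered aromatic ring of carbon only, do not behave alike on this amide-type nitrogen, whose other neighbours are: thiocarbonyl carbon. In this assay the exchange gives a 3.4-fold higher number from compound 2 to compound 3 (0.53 log units; beyond the scatter), so the presence of that aromatic ring does not by itself fix the read-out at this place. The other comparison is much weaker, with an at least 1.6-fold lower number from compound 1 to compound 3 (0.22 log units; that floor lies within the scatter), so compound 3 cannot be said to keep a gain that lies beyond the scatter. Only a floor can be read there because compound 1 stands at a limit of the assay and not at a number: the limit of > 100000 nM in this assay, at which 1 of the 3 values shown sits.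

The leaving and entering groups differ together in their carbon and oxygen counts and in their hydrogen-bond donors and acceptors, so these compounds do not separate which difference goes with the higher number. They also leave open how this assay would respond to a group carrying an amine or a carboxylic acid, or to a longer chain, on this nitrogen.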